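Methyl for Cyclopropyl on the Amide Nitrogen of Compound 1

The source may hold more compounds than are shown below. What is called first, only, known or untested is meant among the compounds shown, and "the series" means these compounds.

Measured so far:
compound 1, `O=C(/C=C1\CCc2cc(Cl)ccc21)NC1CC1`, 17%
compound 2, `NC(=O)/C=C1\CCc2cc(F)c(F)cc21`, 100%

Both compounds were tested in a functional assay on the whole organism with Mus musculus as the target, at a dose of 100 mg/kg by the intraperitoneal route; a lower number here means less inhibition, a higher number more inhibition at the dose given (going by the name of the read-out). Compound 1 gives 17%, the lower of the two numbers. Compound 2 gives 100%, a difference far beyond the usual scatter; the two structures differ in more than one place, so what lies behind that gap cannot be read from these two values alone.

Compound 3, `CNC(=O)/C=C1\CCc2cc(Cl)ccc21`, has not yet been measured. It differs from compound 1 in one place: methyl in place of cyclopropyl on an amide-type nitrogen, the difference being cyclopropylamino to methylamino. Among the measured compounds shown here, no measured pair shows the effect of this change, so the expectation rests only on compound 1 and compound 2. A moderate rise beyond the scatter is expected for the step of a number 18 percentage points higher from compound 1 to compound 3 (beyond the scatter). For compound 3 the expected value in this assay is 35%, within a wide range from 5% to 75%.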

Compound 3, a percentage reported as inhibition, in the whole organism at one dose (the size of the read-out at that dose, not a potency): 50%
The estimate for compound 3 lay 15 percentage points below the measured number; low and high end bracket the measured number.
By their numbers in this assay, from the lowest: compound 1; then compound 3; then compound 2.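

In this assay, the group on the amide-type nitrogen matters on its own: with the rest of the molecule unchanged, methyl in place of cyclopropyl gives a number 33 percentage points higher from compound 1 to compound 3 (beyond the scatter) in a large step. The two earlier compounds differed in more than one place, so neither this position nor any other could be judged from them, whereas this pair isolates a single change and shows that the whole-animal read-out responds to it. The data at hand give no explanation of why methyl gives the higher number.

From the compounds shown here alone, it remains open whether the rise continues or reverses with other groups on this nitrogen, such as ethyl or isopropyl. Also open, going by these compounds, is how the amide hydrogen in place of methyl would compare on the core of compound 3, with its chlorine unchanged.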